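A few compounds are considered here, and "the series" means these few. Any claim that something is new, unique, unknown or untested is made for them only; others in the source may bear on it.

Among the measured compounds shown here, compound 2 `Cc1ccccc1N1CCC(=O)N1` gives 8200 nM in an assay on isolated protein for inhibition of Polyunsaturated fatty acid 5-lipoxygenase (Homo sapiens) (a higher number here means a weaker inhibitor, a lower number a stronger inhibitor), and stands as the higher of the two numbers measured so far. Compound 1 `O=C1CCCN(c2cccc(Cl)c2)N1` gives 2500 nM in this assay, a lower number, and the gap to compound 2 lies beyond the usual scatter. Compound 3 `O=C1CCN(c2ccccc2Cl)N1` is not yet measured; it differs from compound 2 by chloro in place of methyl on an aromatic carbon. For the measured compounds named here, no step between measured compounds is known here, so the expectation for compound 3 rests on the two values alone. A modest move toward a lower number is expected, as a 1.6-fold lower number from compound 2 to compound 3 (0.21 log units; within the scatter). Compound 3 is estimated at 5000 nM, with a range from 1800 nM to 14000 nM in this assay.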

Compound 3, half-maximal inhibitory concentration: 3700 nM
Compound 3: middle estimate off by 1.4-fold (0.13 log units), on the high side, within the range that was stated.
By their numbers in this assay, from the lowest: compounds 1 and 3 (each within the scatter of the next); then compound 2.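

In this assay, among the compounds shown here, the swap of methyl for chloro on an aromatic carbon gives a 2.2-fold lower number from compound 2 to compound 3 (0.35 log units; beyond the scatter) and is the first change here made in one place only. It shows that this position responds to the group it carries, even when the heavy-atom count stays the same and neither group has a hydrogen-bond donor or acceptor. No measurement here bears on why the number falls. From the compounds shown here alone, whether a fluoro, a methoxy or an amine at this position would lower the number further remains open. So does whether the same swap would give a similar step on the core of compound 1.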